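A pyridinyl ring in place of cyanophenyl on the core

The source may report more compounds than this note shows. Statements on the series, on what has been measured and on what is new or still open speak of the compounds shown alone.

Of the compounds shown here, three sharing one core have been tested in a functional assay on HCT-116 cells (Homo sapiens) for inhibition, read by MTT assay, with a stated time of 24 h, tested at 10 uM; a lower number here means less inhibition of growth, a higher number more inhibition of growth at the concentration tested. Compound 1 `N#Cc1ccc(-c2cnc3[nH]cc(-c4nnc(-c5ccc(F)cc5)o4)c(=O)c3c2)cc1` gives 18.9%. Compound 2 `N#Cc1ccc(-c2cnc3[nH]cc(-c4nnc(-c5ccc(Cl)cc5)o4)c(=O)c3c2)cc1` gives 18.3%, and compound 3 `CS(=O)(=O)c1ccc(-c2cnc3[nH]cc(-c4nnc(-c5cccnc5)o4)c(=O)c3c2)cc1` gives 14.7%. All three numbers lie within the usual scatter of one another, so compound 1 cannot be set apart from the other two; it simply sits in the same narrow band. For the measured compounds named here, the one single-point change among them, a number 0.6 percentage points lower from compound 1 to compound 2 (within the scatter), shows that swapping one halogen for another on the outer ring left the read-out unchanged beyond the scatter.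

Compound 4 `O=c1c(-c2nnc(-c3ccc(F)cc3)o2)c[nH]c2ncc(-c3ccncc3)cc12` differs from compound 1 by pyridin-4-yl in place of 4-cyanophenyl on an aromatic carbon. Going by the values given here, no measured pair bears directly on this change, and compound 3 differs from compound 1 in two places at once, so it cannot be used to isolate it. With every measured number sitting close together, the expectation for compound 4 is a step of a number 2.9 percentage points lower from compound 1 to compound 4 (within the scatter), which is within the scatter. Compound 4 is therefore estimated at 16% in this assay, with a range from 5% to 28%.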

Compound 4, percent growth inhibition at one concentration: 20.5%
Beside the measured number, compound 4's estimate is 4.5 percentage points below it, and the stated range covers the measured number.
By their numbers in this assay, from the lowest: compounds 3, 2, 1 and 4 (each within the scatter of the next).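

Read in this assay the change to pyridin-4-yl in place of 4-cyanophenyl on this aromatic carbon of the shared core gives a number 1.6 percentage points higher from compound 1 to compound 4 (within the scatter) and is the first single change measured at this position. The nitrile and its carbon-only aromatic ring can therefore give way to a six-membered aromatic ring with a ring nitrogen without moving growth inhibition beyond the scatter, so this pair shows no sign that the read-out depends on which of these two rings sits here. No measurement is available to explain this result.

From the compounds shown here alone, whether an amine, a carboxylic acid or a longer chain on this carbon would move the read-out beyond the scatter remains open. Also open, going by these compounds, is whether pyridin-4-yl would give the same outcome with the chloro group of compound 2 on the outer ring.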